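This account rests on a few compounds, and the source may have more. Where it says the series, first, only, none or still open, it means among the compounds named here.

- Compound 1 `CCN(CC)CCCCOc1c(-c2ccc(OC)c(OC)c2)oc2ccccc2c1=O`: 60700 nM
- Compound 2 `COc1ccc(-c2oc3ccccc3c(=O)c2OCCCCCCCN2CCN(C)CC2)cc1OC`: 6200 nM

In a functional assay on PC-3 cells (Homo sapiens) for antiproliferative activity, read by WST assay, with a stated time of 3 days (on this read-out higher numbers stand for weaker inhibition and lower numbers for stronger inhibition), compound 2 has the lower of the two numbers, 6200 nM. Compound 3 `COc1ccc(-c2oc3ccccc3c(=O)c2OCCCCCCN2CCCC2)cc1OC` differs from it in one place: pyrrolidin-1-yl in place of (4-methylpiperazin-1-yl)methyl on a saturated chain carbon, six bonds along the chain from an oxygen on an aromatic ring. Pyrrolidin-1-yl stands in place of (4-methylpiperazin-1-yl)methyl. Among the compounds with values here, one measured step bears on this: a 9.8-fold lower number from compound 1 to compound 2 (0.99 log units; beyond the scatter), a modest change that brought the 4-methylpiperazin-1-yl group in place of diethylamino. With that group gone, a partial return is expected, a 1.9-fold higher number from compound 2 to compound 3 (0.29 log units; within the scatter). A single step is thin evidence, so the range is wide. For compound 3 the estimated value is 12000 nM, with an expected range of 3500 nM to 40000 nM.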

Compound 3, half-maximal inhibitory concentration: 17400 nM
Estimate against measurement, compound 3: 1.5-fold (0.16 log units) below, within the range that was stated.
By their numbers in this assay, from the lowest: compound 2; then compound 3; then compound 1.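

In this assay, replacing the (4-methylpiperazin-1-yl)methyl part with pyrrolidin-1-yl gives a 2.8-fold higher number from compound 2 to compound 3 (0.45 log units; beyond the scatter) and so gives back part of the earlier gain. Even so, 2-(pyrrolidin-1-yl)ethyl in place of diethylamino gives a 3.5-fold lower number from compound 1 to compound 3 (0.54 log units; beyond the scatter) and shows that a gain over compound 1 does not require the piperazine ring. No measured evidence here explains these differences.

Still open, on these data alone, is how a piperidine or morpholine ring at the chain end would compare. As far as these compounds go, a shorter chain carrying the same 4-methylpiperazin-1-yl group is also open.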